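Bromo to Nitro on the Aryl Urea: Expected Inhibition

The source may report more compounds than this note shows. Statements on the series, on what has been measured and on what is new or still open speak of the compounds shown alone.

Measured compounds:
- compound 1, `Cc1ccc(NC(=O)Nn2c(C)nc3ccccc3c2=O)cc1`: 52%
- compound 2, `Cc1nc2ccccc2c(=O)n1NC(=O)Nc1ccc(Br)cc1`: 51%

Of the compounds shown here, two sharing one core have been tested in a functional assay on the whole organism for inhibition, with Mus musculus as the target, with a stated time of 1 h, at a dose of 100 mg/kg by the intraperitoneal route; on this read-out higher numbers stand for more inhibition at the one dose given (going by the name of the read-out) and lower numbers for less inhibition. In this assay compound 1 gives 52%, and compound 2 gives 51%. Going by the values given here, the one step that connects them, a number 1 percentage points lower from compound 1 to compound 2 (within the scatter), is within the scatter, so the two numbers cannot be told apart. Compound 2 holds the lower of the two numbers, but only by a margin the measurement itself does not resolve, so it stands level with compound 1.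

Compound 3, `Cc1nc2ccccc2c(=O)n1NC(=O)Nc1ccc([N+](=O)[O-])cc1`, is the next member of the series. The change from compound 2 is nitro in place of bromo on an aromatic carbon. Among the compounds with values here, the only measured step at this same position is the one from compound 1 to compound 2, and it was within the scatter. With one such precedent, the expectation is that replacing the group at this position again leaves the read-out roughly where it is, and so the step of a number 1 percentage points lower from compound 2 to compound 3 (within the scatter) is estimated to stay within the scatter in either direction. Compound 3 is therefore expected to give about 50%, with a range from 30% to 70%.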

Compound 3, a percentage reported as inhibition, in the whole organism at one dose (the size of the read-out at that dose, not a potency): 40%
Estimate against measurement, compound 3: 10 percentage points above; the range from low to high includes it.
By their numbers in this assay, from the lowest: compound 3; then compounds 2 and 1 (each within the scatter of the next).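

Methyl and bromo gave numbers within the scatter of each other in this assay, so this place on the aromatic ring, para to a large group, could have seemed indifferent to the group it carries. Nitro shows that the read-out can respond to a change here, with a number 11 percentage points lower from compound 2 to compound 3 (beyond the scatter), and the comparison with the methyl compound gives much the same picture, with a number 12 percentage points lower from compound 1 to compound 3 (beyond the scatter), so both steps are modest but beyond the scatter and compound 3 stands lowest of the three. Nitro brings more heavy atoms and two hydrogen-bond acceptors where bromo has none, but nothing available explains the lower number or singles out one of these differences as the one that counts.

Going by these compounds, with a single nitro compound, it remains open whether the lower number is particular to nitro or would also appear with other groups at this place, such as an amine, a carboxylic acid or a methoxy group. All three numbers also come from one dose, so they give the size of the inhibition at that dose and say nothing about potency.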